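The compounds below may be only part of what the source reports. "The series", "measured", "known", "first", "only" and "open" are said of these compounds alone.

Measured so far in a functional assay on P388 cells (Mus musculus) for inhibition; on this read-out higher numbers stand for weaker inhibition and lower numbers for stronger inhibition:

compound 1, `O=C1/C(=C/c2ccc(Cl)cc2)CCCc2ccccc21`: 9500 nM
compound 2, `O=C1/C(=C/c2ccc(Br)cc2)CCCc2ccccc21`: 18600 nM
compound 3, `O=C1CCCCC/C1=C\c1ccc(Cl)cc1`: 19100 nM

Compound 1 and compound 2 share a core and differ in one place only, (bromo in place of chloro on an aromatic carbon). The step of a 2.0-fold higher number from compound 1 to compound 2 (0.29 log units; within the scatter). Compound 3 sits on a different core; how the core of compound 3 differs from the core of compound 1 is not broken down here. The value of compound 3 and the value of compound 2 lie within the scatter of each other, as do the value of compound 3 and the value of compound 1, so no order among the three can be read from these numbers.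

Compound 4, `O=C1CCCCC/C1=C\c1ccc(Br)cc1`, has not been measured. It differs from compound 3 by bromo in place of chloro on an aromatic carbon. Among the compounds with values here, this is the same kind of change as the one from compound 1 to compound 2, but not the same: in the pair already measured the place is para to a large group, while here it is para to a group of 9 heavy atoms. Among the compounds shown the change occurs twice in all, once with a measurement.

For compound 4 the expected step in this assay is a 1.6-fold higher number from compound 3 to compound 4 (0.20 log units; within the scatter). Within the data shown here, this expectation rests on the one measured step of the same kind, a 2.0-fold higher number from compound 1 to compound 2 (0.29 log units; within the scatter), and on nothing else, since the two cores are not compared in any counted way. Compound 4 is therefore estimated at 30000 nM, with a range from 12000 nM to 75000 nM.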

Compound 4, half-maximal inhibitory concentration: 16800 nM
Beside the measured number, compound 4's estimate is 1.8-fold (0.25 log units) above it; the measured number falls inside the stated range.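

In this assay, bromo in place of chloro on an aromatic carbon gives a 1.1-fold lower number from compound 3 to compound 4 (0.06 log units; within the scatter), a step that cannot be told apart from no change. Set beside the earlier step on the other core, this gives no sign that the outcome of the exchange depends on the core, and within these two pairs an estimate carried from one core to the other holds up only as far as the scatter allows: the same change on two cores in this assay, a 2.0-fold higher number (0.29 log units; within the scatter) from compound 1 to compound 2 and a 1.1-fold lower number (0.06 log units; within the scatter) from compound 3 to compound 4, 2.2-fold (0.35 log units) apart, within the scatter of two such steps

This does not show that the step is the same on both cores, since each step lies within the scatter, neither has an established direction, and a small dependence on the core could stay hidden in two pairs.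

The compounds shown leave open whether any group other than chloro or bromo at this place, such as fluoro, methoxy, an amine or a carboxylic acid, would move the number beyond the scatter. They also leave open whether the near silence of the chloro-to-bromo exchange would persist on cores other than these two, or with the halogen placed elsewhere on the aromatic ring.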